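The source may hold more compounds than are shown below. What is called first, only, known or untested is meant among the compounds shown, and "the series" means these compounds.

Working notes on the series. The shared core is that of compound 1 `O=S(=O)(NC1=NCCN1C(=S)SN1CCn2c1nsc2=S)c1ccc(C(F)(F)F)cc1`, with variation at a single aromatic carbon. In a functional assay on KYSE-510 cells (Homo sapiens) for antiproliferative activity, read by crystal violet staining, with a stated time of 96 h (a lower number here means a stronger inhibitor of growth, a higher number a weaker inhibitor of growth), compound 1 gives >= 20000 nM, which is a limit of the assay and not a number. Compound 2 `O=[N+]([O-])c1ccc(S(=O)(=O)NC2=NCCN2C(=S)SN2CCn3c2nsc3=S)cc1` carries nitro in place of trifluoromethyl on an aromatic carbon. In this assay compound 2 gives >= 20000 nM, again a limit of the assay rather than a number. The step that the two limits leave unreadable from compound 1 to compound 2 cannot be read because of the limit of >= 20000 nM in this assay, at which 2 of the 2 values shown sit. Compound 2 therefore stands only at a limit, with no number that places it more precisely, and compound 1 stands at the same limit.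

Compound 3 `O=S(=O)(NC1=NCCN1C(=S)SN1CCn2c1nsc2=S)c1ccc(Oc2ccccc2)cc1` differs from compound 2 by phenoxy in place of nitro on an aromatic carbon. Going by the values given here, only one measured step bears on this change, a step that the two limits leave unreadable from compound 1 to compound 2, and it is unreadable; no change at this aromatic carbon has so far produced a readable number in this assay. The step of a number no higher from compound 2 to compound 3 (the limit leaves the size open) is accordingly estimated as no more than the scatter, in no particular direction. Compound 3 is expected to give 20000 nM in this assay, within a range from 5000 nM to 60000 nM, and the result may well be reported again only as a limit.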

Compound 3, concentration for 50% growth inhibition: >= 20000 nM
Compound 3 gave a limit, no number; the forecaster's own chance of this, stated with the estimate: 70%; the middle value lies on the limit itself.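

In this assay compound 3 gives >= 20000 nM, a limit of the assay and not a number. Going by these compounds alone, no new step among compound 1, compound 2 and compound 3 can be read: the limit of >= 20000 nM in this assay, at which 3 of the 3 values shown sit. The compounds shown leave open whether any group at this aromatic carbon changes growth inhibition in this assay.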